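Chloro Added to the Phenyl Ring of Compound 4

A few compounds are considered here, and "the series" means these few. Any claim that something is new, unique, unknown or untested is made for them only; others in the source may bear on it.

Three measured compounds share one core and differ only in the group on one aromatic carbon of that core. Compound 1 `Cc1ccc2nc(NC(=O)/C=C/c3ccccc3)sc2c1` bears a methyl there; in a functional assay on the whole organism (Hindlimb, strain albino) with Mus musculus as the target, in the maximal electroshock model, with a stated time of 0.5 h (on this read-out higher numbers stand for an effect only at larger amounts of compound and lower numbers for an effect already at smaller amounts), compound 1 gives 380 umol/kg. Compound 2 `O=C(/C=C/c1ccccc1)Nc1nc2ccc(Cl)cc2s1` carries a chloro instead, and in this assay compound 2 gives 425 umol/kg. Compound 3 `O=C(/C=C/c1ccccc1)Nc1nc2ccc([N+](=O)[O-])cc2s1` carries a nitro, and in this assay compound 3 gives 485 umol/kg. The three steps among them, a 1.1-fold higher number from compound 1 to compound 2 (0.05 log units; within the scatter), a 1.3-fold higher number from compound 1 to compound 3 (0.11 log units; within the scatter) and a 1.1-fold higher number from compound 2 to compound 3 (0.06 log units; within the scatter), all lie within the scatter. Compound 3 thus holds the highest of the three numbers, yet its neighbours stand so close that nothing separates them beyond the noise.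

Compound 4 `O=C(/C=C/c1ccc(Cl)cc1)Nc1nc2ccc([N+](=O)[O-])cc2s1` keeps the nitro of compound 3 and differs from it in chloro in place of hydrogen on an aromatic carbon, a change at the other end of the molecule, phenyl to 4-chlorophenyl. Among the measured compounds shown here, none of the measured steps touches that ring; the only comparison at hand is that a chloro on the core, in compound 2, sat within the scatter of its neighbours. The step of a 1.1-fold lower number from compound 3 to compound 4 (0.03 log units; within the scatter) is therefore expected to be small, with no direction favoured. Compound 4 is expected to give about 450 umol/kg in this assay, within a range from 250 umol/kg to 800 umol/kg.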

Compound 4, dose for half-maximal effect: 259 umol/kg
Compound 4: middle estimate off by 1.7-fold (0.24 log units), on the high side; the measured number falls inside the stated range.
By their numbers in this assay, from the lowest: compounds 4, 1, 2 and 3 (each within the scatter of the next).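

Replacing phenyl with 4-chlorophenyl in this assay gives a 1.9-fold lower number from compound 3 to compound 4 (0.27 log units; within the scatter) and so shows that this position, on a six-membered aromatic ring of carbon only and para to a large group, accepts a chloro with no shift that stands clear of the noise. Among the compounds shown here, this is the largest step among the four compounds and the only one on this ring, yet it remains within the scatter, so this single pair does not establish the ring as a place where substitution moves the number any more than the three steps on the shared core do. No available evidence explains the size of this step.

From the compounds shown here alone, the reading rests on one pair with a nitro on the core, so it remains open whether 4-chlorophenyl would give a similar step alongside the methyl of compound 1 or the chloro of compound 2. Going by these compounds, it is also open whether a different group at this position, such as an amine, a carboxylic acid or a longer alkyl chain, would produce a step beyond the scatter in either direction.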